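The source may hold more compounds than are shown below. What is called first, only, known or untested is meant among the compounds shown, and "the series" means these compounds.

Compound 3 `Fc1cccc(-c2nc(Nc3cccc(Cl)c3)c3cc(F)ccc3n2)c1` carries a 3-chlorophenyl group on the amino nitrogen of the shared core. In a functional assay on HT29-AK cells (Homo sapiens) for cytotoxicity, read by MTT assay, with a stated time of 48 h (a lower number here means a stronger inhibitor, a higher number a weaker inhibitor), compound 3 gives only a limit, > 50000 nM. Compound 1 `Fc1cccc(-c2nc(Nc3ccccc3)c3cc(F)ccc3n2)c1`, with plain phenyl at that nitrogen, gives 48300 nM in this assay. Compound 2 `Fc1ccc(Nc2nc(-c3cccc(F)c3)nc3ccc(F)cc23)cc1`, with 4-fluorophenyl there, likewise gives only a limit, > 50000 nM. So an at least 1.0-fold higher number from compound 1 to compound 3 (0.01 log units; that floor lies within the scatter) and an at least 1.0-fold higher number from compound 1 to compound 2 (0.01 log units; that floor lies within the scatter) are floors rather than sizes, and a step that the two limits leave unreadable from compound 2 to compound 3 cannot be read; the limit of > 50000 nM in this assay, at which 2 of the 3 values shown sit, shows how much of the set sits there. Compound 4 `Fc1cccc(-c2nc(Nc3ccccc3Cl)c3cc(F)ccc3n2)c1` differs from compound 3 only in 2-chlorophenyl in place of 3-chlorophenyl on a nitrogen on an aromatic ring. Because an at least 1.0-fold higher number from compound 1 to compound 3 (0.01 log units; that floor lies within the scatter) and a step that the two limits leave unreadable from compound 2 to compound 3 give no readable size, no step beyond the scatter is expected in this assay, so a step that the limit leaves unreadable from compound 3 to compound 4 is the estimate. Compound 4 is expected at 60000 nM, within 25000 nM to 150000 nM.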

Compound 4, half-maximal inhibitory concentration: > 50000 nM
Compound 4: only a limit was reported; the forecaster's own chance of this, stated with the estimate: 70%; the middle value lies beyond the limit too.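

In this assay, 2-chlorophenyl in place of 3-chlorophenyl on the nitrogen also ends at a limit, so this change of chlorine position shows no readable effect, and the steps to compound 4 from compound 3 and compound 2 cannot be read. The step of an at least 1.0-fold higher number from compound 1 to compound 4 (0.01 log units; that floor lies within the scatter) is a floor and not a size. Most of the set now rests at one limit: the limit of > 50000 nM in this assay, at which 3 of the 4 values shown sit.

Going by these compounds, whether an amine or a carboxylic acid on the phenyl ring at this nitrogen would bring a value under that limit stays open.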